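A few compounds are considered here, and "the series" means these few. Any claim that something is new, unique, unknown or untested is made for them only; others in the source may bear on it.

In an ADME assay on the whole organism for pharmacokinetics, with Rattus norvegicus as the target, at a dose of 2 mg/kg by the intravenous route (a higher number here means faster removal of the compound, a lower number slower removal), compound 1 (`CC(C)(O)c1ccc(-c2cnc3c(n2)N(CC2CCCCC2)CC(=O)N3)cn1`) has no number to offer, since its entry reads "not determined" (no result reported) and no result was reported. Compound 2 (`CC(C)(O)c1ccc(-c2cnc3c(n2)N(CC2CCOCC2)C(=O)CN3)cn1`) is in the same position with "not determined" (no result reported) as its entry. Only compound 3 (`CO[C@H]1CC[C@H](N2C(=O)CNc3ncc(-c4ccc(C(C)(C)O)nc4)nc32)CC1`) gives a measured clearance of 4.9 mL/min/kg in this series, so it is the sole reference point available. The structural step of interest leads from compound 1 to compound 4 (`CO[C@H]1CC[C@H](N2CC(=O)Nc3ncc(-c4ccc(C(C)(C)O)nc4)nc32)CC1`). It is 4-methoxycyclohexyl in place of cyclohexylmethyl on a nitrogen on an aromatic ring in a ring and leaves the rest of compound 1 unchanged. Among the measured compounds shown here, the new group brings in a hydrogen-bond acceptor, but no step can be sized from compound 1, and no measured pair shows what such a swap does to clearance. The expectation therefore rests on compound 3 at 4.9 mL/min/kg and is for no step beyond the usual scatter from that number, though with wide uncertainty and a slight lean towards faster removal. For compound 4 the estimated clearance is 8 mL/min/kg within an expected range of 3 mL/min/kg to 22 mL/min/kg in this assay once measured.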

Compound 4, clearance: 1.7 mL/min/kg
Estimate against measurement, compound 4: 4.7-fold (0.67 log units) above; the measured number lies below the stated range.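

In this assay, among the compounds shown here, compound 4 gives 1.7 mL/min/kg and no step from compound 1 can be read. The compounds shown leave open what 4-methoxycyclohexyl in place of cyclohexylmethyl does to clearance. Nothing shown here offers an explanation for this value.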